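The source may report more compounds than this note shows. Statements on the series, on what has been measured and on what is new or still open speak of the compounds shown alone.

Measured so far in a functional assay on A549 cells (Homo sapiens) for cytotoxicity, read by MTT assay, with a stated time of 72 h; on this read-out higher numbers stand for weaker inhibition and lower numbers for stronger inhibition (all values from this read-out):
- compound 1 `CNC(=O)c1cc(Oc2ccc(NC(=O)c3nn(-c4ccccc4C(F)(F)F)c(=O)cc3C)cc2F)ccn1` gives > 40000 nM (a limit)
- compound 2 `Cc1cc(=O)n(-c2ccc(Br)cc2F)nc1C(=O)Nc1ccc(Oc2ncnc3ccsc23)cc1` gives 7930 nM (a number)

Going by the values given here, compound 2 at 7930 nM is the only actual number so far. Compound 1 at > 40000 nM is a limit of the assay and not a number.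

The next compound is compound 3 `Cc1cc(=O)n(-c2cccc(F)c2)nc1C(=O)Nc1ccc(Oc2ncnc3ccsc23)cc1` which keeps everything in compound 2 except one group. The change is 3-fluorophenyl in place of 4-bromo-2-fluorophenyl on an aromatic nitrogen and it puts 3-fluorophenyl in place of 4-bromo-2-fluorophenyl on an aromatic nitrogen.

Among the compounds with values here, no measured pair in this assay yet shows what a change of this kind does, so the expectation stays modest. No step beyond the usual scatter is expected, and any drift should run towards weaker inhibition. Compound 3 may also read out only as a limit.

The expected move is a 1.4-fold higher number from compound 2 to compound 3 (0.14 log units; within the scatter) in the estimate made here. For compound 3 the estimated value is 11000 nM with an expected range from 3500 nM to 35000 nM on this read-out.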

Compound 3, half-maximal inhibitory concentration: 9540 nM
Beside the measured number, compound 3's estimate is 1.2-fold (0.06 log units) above it; low and high end bracket the measured number.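

In this assay, going by these compounds alone, 3-fluorophenyl in place of 4-bromo-2-fluorophenyl on the aromatic nitrogen gives the first readable step, a 1.2-fold higher number from compound 2 to compound 3 (0.08 log units; within the scatter), so this pair gives no sign that the number depends on which of these two aryl groups is present. The bromine can therefore leave and the fluorine can change its place on the phenyl ring with no effect that can be told from the scatter, at least on this shared core. Both edits fall within one step, though, so the pair cannot separate what the bromine and the fluorine each contribute.

Within the data shown here, compound 1 gives > 40000 nM, which is a limit and not a number, and no step to it can be read. Still open, as far as these compounds go, is whether a phenyl ring carrying an amine or a carboxylic acid, or a longer alkyl chain in place of the ring, on this aromatic nitrogen would move the number away from the values of compound 2 and compound 3 or towards the end of the measurable range: the limit of > 40000 nM in this assay, at which 1 of the 3 values shown sits.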